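Methyl in Place of Chloro: From Compound 2 to Compound 4

This account rests on a few compounds, and the source may have more. Where it says the series, first, only, none or still open, it means among the compounds named here.

Of the compounds shown here, three that share one core have been measured. In a functional assay on MCF7 cells (Homo sapiens) for antiproliferative activity, read by MTT assay, with a stated time of 48 h (a higher number here means a weaker inhibitor, a lower number a stronger inhibitor), compound 1 `O=C(Nc1cccc(/C=C/C(=O)c2nc3ccccc3[nH]2)c1)c1cccc(Cl)c1` gives 7840 nM. Compound 2 `O=C(Nc1cccc(/C=C/C(=O)c2nc3ccccc3[nH]2)c1)c1ccc(Cl)cc1` gives 8410 nM in this assay, and compound 3 `O=C(Nc1cccc(/C=C/C(=O)c2nc3ccccc3[nH]2)c1)c1ccc(Br)cc1` gives 7000 nM. Compound 2 shows the highest of the three numbers, yet the step of a 1.1-fold higher number from compound 1 to compound 2 (0.03 log units; within the scatter) and the step of a 1.2-fold lower number from compound 2 to compound 3 (0.08 log units; within the scatter) are both within the scatter, so nothing separates compound 2 from the other two in this assay.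

Compound 4 `Cc1ccc(C(=O)Nc2cccc(/C=C/C(=O)c3nc4ccccc4[nH]3)c2)cc1` differs from compound 2 by a single exchange: methyl in place of chloro on an aromatic carbon. Among the compounds with values here, no measured pair swaps a halogen for a methyl, so the bearing steps are only those among the halogenated compounds: a 1.1-fold higher number from compound 1 to compound 2 (0.03 log units; within the scatter), a 1.1-fold lower number from compound 1 to compound 3 (0.05 log units; within the scatter) and a 1.2-fold lower number from compound 2 to compound 3 (0.08 log units; within the scatter). Each of these is within the scatter, which shows that the ring carrying the amide carbonyl tolerates changes of substituent position and halogen identity without a shift in this assay. Within the data shown here, the methyl is a different kind of group, but there is no measured step that points in either direction for it.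

The step of a 1.0-fold lower number from compound 2 to compound 4 (0.00 log units; within the scatter) is therefore expected to stay within the scatter. For compound 4 the estimate in this assay is 8400 nM, with a range from 4000 nM to 18000 nM.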

Compound 4, half-maximal inhibitory concentration: 9690 nM
Compound 4: the middle estimate sits 1.2-fold (0.06 log units) below what was measured; measured number inside the range.
By their numbers in this assay, from the lowest: compounds 3, 1, 2 and 4 (each within the scatter of the next).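

The exchange of a halogen for methyl on this aromatic carbon, para to a large group, now has a measured outcome in this assay: the step is a 1.2-fold higher number from compound 2 to compound 4 (0.06 log units; within the scatter) and the matching exchange from bromo gives a 1.4-fold higher number from compound 3 to compound 4 (0.14 log units; within the scatter), so neither halogen is needed to hold the number where it stands. The step of a 1.2-fold higher number from compound 1 to compound 4 (0.09 log units; within the scatter) extends this to the comparison between 4-methylphenyl and 3-chlorophenyl on the carbonyl carbon, and all four compounds thus lie within the scatter of their neighbours, with chloro, bromo and methyl not separated at this place. Why these three groups read alike cannot be said from these numbers, and nothing measured here speaks to a cause (no supporting data bear on it).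

The compounds shown leave open whether this tolerance reaches beyond single-atom substituents of this kind, since an amine, a carboxylic acid or a longer chain such as butyl on the same carbon would test it. They also leave open whether methyl behaves the same way at the position held by the chloro of the 3-chlorophenyl group.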